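This account rests on a few compounds, and the source may have more. Where it says the series, first, only, none or still open, it means among the compounds named here.

Measured compounds:
- compound 1 `O=C1NC(=O)/C(=C/c2cn(-c3ccccc3)nc2-c2ccccc2)S1`: 53% in a functional assay on the whole organism (strain Wistar albino) for inhibition, with Rattus norvegicus as the target, read by paw edema, in the formalin test, with a stated time of 7 days, at a dose of 20 mg/kg by the oral route; on this read-out lower numbers stand for less inhibition and higher numbers for more inhibition at the one dose given (going by the name of the read-out)
- compound 2 `O=C1NC(=O)/C(=C/c2cn(-c3ccccc3)nc2-c2ccc(Cl)cc2)S1`: 42%

Among the compounds with values here, compound 2 stands lowest of the two numbers so far. Within the data shown here, its nearest neighbour is compound 1, and the one step between them, a number 11 percentage points lower from compound 1 to compound 2 (beyond the scatter), is the only measured step; it concerns chloro in place of hydrogen on an aromatic carbon and runs downward by a modest but real amount.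

Compound 3 `O=C1NC(=O)/C(=C/c2cn(-c3ccc([N+](=O)[O-])cc3)nc2-c2ccc(Cl)cc2)S1` differs from compound 2 as follows: nitro in place of hydrogen on an aromatic carbon. The only step shown, a number 11 percentage points lower from compound 1 to compound 2 (beyond the scatter), is on a different ring and with a different group (chloro), so it bears on the present change only as a general indication that a single substituent added to one of the phenyl rings has so far moved this assay modestly and downward. Among the measured compounds shown here, no measured step involves a nitro group, and nothing here distinguishes phenyl from 4-nitrophenyl directly, so the expected step is wide: either no change beyond the scatter or a further modest fall.

On that basis compound 3 is expected to give 38% (range 24% to 52%), the step of a number 4 percentage points lower from compound 2 to compound 3 (within the scatter) being the estimate.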

Compound 3, a percentage reported as inhibition, in the whole organism at one dose (the size of the read-out at that dose, not a potency): 51%
For compound 3 the middle estimate is 13 percentage points below the measured one, within the range that was stated.
By their numbers in this assay, from the lowest: compounds 2, 3 and 1 (each within the scatter of the next, the first and the last beyond it).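

In this assay the change from phenyl to 4-nitrophenyl gives a number 9 percentage points higher from compound 2 to compound 3 (within the scatter) so a nitro group on this ring, para to a large group, leaves the read-out at this one dose within the usual spread of repeats. The step on the other phenyl ring, a number 11 percentage points lower from compound 1 to compound 2 (beyond the scatter) therefore does not extend to a rule that any substituent added to a phenyl ring lowers the number, since the one nitro step shown does not go beyond the scatter. Nothing available bears on why the chloro and nitro steps differ in this way.

From the compounds shown here alone, with a single nitro step on a chlorinated background, it remains open whether the same group would read alike on the unchlorinated core of compound 1, or whether a step of this kind would hold at other doses. Also open, going by these compounds, is how this position responds to groups of another kind, such as an amine, a carboxylic acid or a longer alkyl chain in place of the nitro group.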